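The source may hold more compounds than are shown below. What is called first, only, known or untested is meant among the compounds shown, and "the series" means these compounds.

The measured compounds:

Compound 1 `CCCCCCCCNC[C@@H]1OC[C@H](N)[C@@H]1O`; in a functional assay on A549 cells (Homo sapiens) for antiproliferative activity, read by MTT assay, with a stated time of 72 h (a higher number here means a weaker inhibitor, a lower number a stronger inhibitor), compound 1 gives > 128000 nM, which is a limit of the assay rather than a number (the limit of > 128000 nM in this assay, at which 1 of the 3 values shown sits).
Compound 2 `CCCCCCCCCCCNC[C@@H]1OC[C@H](N)[C@@H]1O`; in this assay compound 2 gives 11100 nM.
Compound 3 `CCCCCCCCCCCCNC[C@@H]1OC[C@H](N)[C@@H]1O`; in this assay compound 3 gives 5870 nM.

All three share the same core and differ only along one saturated chain. Compound 3 differs from compound 2 by methyl in place of hydrogen on a saturated chain carbon, ten or more bonds along the chain from an amine nitrogen, and the two values lie close together: a 1.9-fold lower number from compound 2 to compound 3 (0.28 log units; within the scatter), which is within the usual scatter, so no order between them can be read. Compound 1 differs from compound 2 by hydrogen in place of propyl on a saturated chain carbon, eight bonds along the chain from an amine nitrogen, and this shortening made a large step: an at least 11-fold higher number from compound 2 to compound 1 (1.06 log units; beyond the scatter).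

Compound 4 `CCCCCCCCCNC[C@@H]1OC[C@H](N)[C@@H]1O` has not yet been measured. It differs from compound 3 by hydrogen in place of propyl on a saturated chain carbon, nine bonds along the chain from an amine nitrogen. This is the same kind of change as that from compound 2 to compound 1, though not the same, as the place reads nine bonds along the chain from an amine nitrogen rather than eight. A step of comparable size is therefore expected, a 10-fold higher number from compound 3 to compound 4 (1.01 log units; beyond the scatter), and this expectation rests on the step of an at least 11-fold higher number from compound 2 to compound 1 (1.06 log units; beyond the scatter) seen between compound 2 and compound 1. Compound 4 is estimated at 60000 nM. The expected range for compound 4 runs from 25000 nM to 150000 nM.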

Compound 4, half-maximal inhibitory concentration: 22100 nM
The estimate for compound 4 lay 2.7-fold (0.43 log units) above the measured number, and the stated range ends above it.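

In this assay, hydrogen in place of propyl gives a 3.8-fold higher number from compound 3 to compound 4 (0.58 log units; beyond the scatter), while a 2.0-fold higher number from compound 2 to compound 4 (0.30 log units; within the scatter) leaves no order to read for that pair. Hydrogen in place of propyl raises the number in both pairs where it occurs, so the direction carries over from one core to the other, but the size of the step does not: the same change on two cores in this assay, an at least 11-fold higher number (1.06 log units; beyond the scatter) from compound 2 to compound 1 and a 3.8-fold higher number (0.58 log units; beyond the scatter) from compound 3 to compound 4, at least 3.0-fold (0.48 log units) apart, beyond the scatter of two such steps The methyl change tells the same story, with an at least 5.7-fold lower number from compound 1 to compound 4 (0.76 log units; beyond the scatter) set against a step within the scatter, and these few compounds show that such a step cannot simply be transferred, not why the sizes differ: the same change on two cores in this assay, a 1.9-fold lower number (0.28 log units; within the scatter) from compound 2 to compound 3 and an at least 5.7-fold lower number (0.76 log units; beyond the scatter) from compound 1 to compound 4, at least 3.0-fold (0.48 log units) apart, beyond the scatter of two such steps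

On these data alone, compound 1 stands at a limit of the assay rather than at a number, which leaves the true size of its steps open: the limit of > 128000 nM in this assay, at which 1 of the 4 values shown sits. Also open is whether the number would keep falling with a chain longer than that of compound 3, and what a carboxylic acid or a ring at the end of the chain would do.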